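Aryl amine variation on the naphthoquinone-sulfonyl amidine series

This account rests on a few compounds, and the source may have more. Where it says the series, first, only, none or still open, it means among the compounds named here.

In a functional assay on MCF7 cells (Homo sapiens) for cytotoxicity, read by MTT assay, with a stated time of 48 h (on this read-out lower numbers stand for stronger inhibition and higher numbers for weaker inhibition), compound 1 `COc1ccc(N/C(CCNC2=CC(=O)c3ccccc3C2=O)=N\S(=O)(=O)c2ccc(C)cc2)cc1` gives 6030 nM, compound 2 `Cc1ccc(S(=O)(=O)/N=C(/CCNC2=CC(=O)c3ccccc3C2=O)Nc2cccc(C(F)(F)F)c2)cc1` gives 89100 nM, and compound 3 `COc1ccc(N/C(CCNC2=CC(=O)c3ccccc3C2=O)=N\S(=O)(=O)c2ccc(C)cc2)c(OC)c1` gives 30200 nM. Compound 3 therefore stands second highest of the three: the nearest neighbour is compound 2, a 3.0-fold lower number from compound 2 to compound 3 (0.47 log units; beyond the scatter), and the furthest is compound 1, a 5.0-fold higher number from compound 1 to compound 3 (0.70 log units; beyond the scatter).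

The next compound, compound 4 `Cc1ccc(S(=O)(=O)/N=C(/CCNC2=CC(=O)c3ccccc3C2=O)Nc2cc(F)c(F)c(F)c2)cc1`, carries 3,4,5-trifluorophenyl in place of 2,4-dimethoxyphenyl on an amine nitrogen. Among the compounds with values here, two measured steps bear on it. The step from compound 1 to compound 2, a 15-fold higher number from compound 1 to compound 2 (1.17 log units; beyond the scatter), shows what an aryl group of this kind did on the amine nitrogen; the step from compound 2 to compound 3, a 3.0-fold lower number from compound 2 to compound 3 (0.47 log units; beyond the scatter), shows the reverse direction with the dimethoxyphenyl of compound 3. Taken together, a rise beyond the scatter is expected in this assay, toward the region of compound 2, though the trifluorophenyl has not itself been tested.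

Compound 4 is expected to give 60000 nM, with a range from 20000 nM to 180000 nM, which means an expected step of a 2.0-fold higher number from compound 3 to compound 4 (0.30 log units; within the scatter).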

Compound 4, half-maximal inhibitory concentration: 6610 nM
For compound 4 the middle estimate is 9.1-fold (0.96 log units) above the measured one, and the stated range ends above it.
By their numbers in this assay, from the lowest: compounds 1 and 4 (each within the scatter of the next); then compound 3; then compound 2.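

In this assay, fluorine on the aryl group at the amine nitrogen does not by itself bring the high number seen with 3-(trifluoromethyl)phenyl: 3,4,5-trifluorophenyl in its place gives a 13-fold lower number from compound 2 to compound 4 (1.13 log units; beyond the scatter). The same group also lowers the number relative to 2,4-dimethoxyphenyl, with a 4.6-fold lower number from compound 3 to compound 4 (0.66 log units; beyond the scatter), and it stands level with 4-methoxyphenyl, with a 1.1-fold higher number from compound 1 to compound 4 (0.04 log units; within the scatter), so a methoxy group is not needed at this position to reach the level of compound 1. No measurement here explains these differences.

Still open, as far as these compounds go, is how a chlorophenyl, a cyanophenyl or a plain phenyl on the amine nitrogen would read against compound 1 and compound 4. Also open, from the compounds shown here alone, is whether a carboxylic acid on the aryl group, or a longer chain in place of the one in the shared core, would keep this level.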